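This account rests on a few compounds, and the source may have more. Where it says the series, first, only, none or still open, it means among the compounds named here.

Within the data shown here, compound 3 `Nc1ccc(-c2cc(=O)c3c(N)cccc3o2)cc1` gives 7.3 nM in a functional assay on MCF7 cells (Homo sapiens) for inhibition, in the absence of a further agent (a higher number here means a weaker inhibitor, a lower number a stronger inhibitor), the highest of the three numbers so far. Among the measured compounds shown here, compound 1 `Nc1ccc(-c2cc(=O)c3c(N)c(Cl)ccc3o2)cc1` gives 3.9 nM in this assay, and compound 2 `Nc1ccc(-c2cc(=O)c3c(N)c(F)cc(F)c3o2)cc1F` gives 1.2 nM, the only value that lies beyond the scatter from compound 3. Compound 4 `Nc1ccc(-c2cc(=O)c3c(N)ccc(O)c3o2)cc1` differs from compound 3 by hydroxy in place of hydrogen on an aromatic carbon. The one measured step of a single change, a 1.9-fold higher number from compound 1 to compound 3 (0.27 log units; within the scatter), concerns a halogen at another position and stayed within the scatter; nothing measured here concerns a hydroxy group, so no shown step bears directly on this change. Compound 4 is therefore expected to sit close to compound 3, with a step of a 1.1-fold higher number from compound 3 to compound 4 (0.04 log units; within the scatter) at most. For compound 4 the estimate is 8 nM, expected between 3 nM and 25 nM.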

Compound 4, half-maximal inhibitory concentration: 5300 nM
Compound 4: middle estimate off by 660-fold (2.82 log units), on the low side, outside the stated range (above it).
By their numbers in this assay, from the lowest: compound 2; then compounds 1 and 3 (each within the scatter of the next); then compound 4.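

Hydroxy in place of hydrogen on this aromatic carbon, para to an amino group, brings a 730-fold higher number from compound 3 to compound 4 (2.86 log units; beyond the scatter) in this assay, so one added group here can change the number far more than anything seen before. The earlier single change, hydrogen in place of chloro on another carbon, gave only a 1.9-fold higher number from compound 1 to compound 3 (0.27 log units; within the scatter) and so gave no sign of such sensitivity in the shared core. Nothing shown gives a reason for this large step. On these data alone, whether a methoxy group or an amine on this carbon would bring a similar loss, or whether it belongs to hydroxy alone, stays open.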